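Swapping the sulfonyl ring and lengthening the linker

The source may hold more compounds than are shown below. What is called first, only, known or untested is meant among the compounds shown, and "the series" means these compounds.

Among the compounds with values here, compound 1 `CCN(C/C=C/C#CC(C)(C)C)Cc1cccc(OCCN(C)S(=O)(=O)c2nccs2)c1` gives 170 nM in a functional assay on HepG2 cells for inhibition of squalene monooxygenase (Homo sapiens) (a higher number here means a weaker inhibitor, a lower number a stronger inhibitor), the lowest of the two numbers measured so far. Within the data shown here, compound 2 `CCN(C/C=C/C#CC(C)(C)C)Cc1cccc(OCCN(C)S(=O)(=O)c2ccc(-c3cccs3)s2)c1` gives 10000 nM in this assay, and the one step between them reads a 59-fold higher number from compound 1 to compound 2 (1.77 log units; beyond the scatter). Compound 3 `CCN(C/C=C/C#CC(C)(C)C)Cc1cccc(OCCCN(C)S(=O)(=O)c2cccs2)c1` differs from compound 1 by a group of 11 heavy atoms (6 carbon, 1 nitrogen, 2 oxygen, 2 sulfur; one five-membered aromatic ring with 1 hetero atom) in place of a group of 10 heavy atoms (4 carbon, 2 nitrogen, 2 oxygen, 2 sulfur; one five-membered aromatic ring with 2 hetero atoms), on a saturated chain carbon, two bonds along the chain from an oxygen on an aromatic ring. Among the measured compounds shown here, only that step bears on this change, and it was large, but it altered the ring on the sulfonyl sulfur alone, whereas here the chain also grows. A modest weakening is therefore expected, a 2.4-fold higher number from compound 1 to compound 3 (0.37 log units; beyond the scatter). Compound 3 is expected to give 400 nM in this assay, within the range 100 nM to 2000 nM.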

Compound 3, half-maximal inhibitory concentration: 6400 nM
The estimate for compound 3 lay 16-fold (1.20 log units) below the measured number; the measured number lies above the stated range.
By their numbers in this assay, from the lowest: compound 1; then compounds 3 and 2 (each within the scatter of the next).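

In this assay, the entering (methyl((thiophen-2-yl)sulfonyl)amino)methyl group brings a 38-fold higher number from compound 1 to compound 3 (1.58 log units; beyond the scatter), so a large loss at this position does not require the two linked rings of compound 2. Here, a single five-membered aromatic ring on the sulfonyl sulfur, carried on a longer chain, is enough for such a loss. Nothing available accounts for this loss. Ring and chain changed together, so the compounds shown cannot assign the loss to either one. A 1,3-thiazol-2-yl ring on the longer chain of compound 3 would separate the two.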